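Removing the chloromethyl end from a urea chain: expected effect

The source may report more compounds than this note shows. Statements on the series, on what has been measured and on what is new or still open speak of the compounds shown alone.

Measured compounds:
compound 1 `CCCc1ccccc1OS(=O)(=O)c1ccc(NC(=O)NCCCCl)cc1` with 13000 nM
compound 2 `Cc1ccccc1NS(=O)(=O)c1cccc(NC(=O)NCCCCl)c1` with 60000 nM
compound 3 `CCCc1ccccc1OS(=O)(=O)c1ccc(NC(=O)NCC)cc1` with 800 nM

These three compounds were tested in a functional assay on M21 cells (Homo sapiens) for cytotoxicity, read by sulforhodamine B assay, with a stated time of 48 h; on this read-out higher numbers stand for weaker inhibition and lower numbers for stronger inhibition. Compound 1 and compound 3 share one core, and the step between them is hydrogen in place of chloromethyl on a saturated chain carbon, two bonds along the chain from an amide-type nitrogen. That step gave a 16-fold lower number from compound 1 to compound 3 (1.21 log units; beyond the scatter), so the shorter chain in compound 3 goes with a clearly stronger effect on the cells.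

Compound 2 has a different core; the difference between the two cores is not broken down here. In this assay compound 2 gives the highest number of the three, and its gap to compound 1 and to compound 3 lies beyond the usual scatter in each case.

Compound 4 `CCNC(=O)Nc1cccc(S(=O)(=O)Nc2ccccc2C)c1` has not yet been measured. Within the data shown here, it differs from compound 2 by hydrogen in place of chloromethyl on a saturated chain carbon, two bonds along the chain from an amide-type nitrogen, which is the same change as the one from compound 1 to compound 3. Because the earlier step gave a 16-fold lower number from compound 1 to compound 3 (1.21 log units; beyond the scatter), the expected step here is a 13-fold lower number from compound 2 to compound 4 (1.12 log units; beyond the scatter), with extra uncertainty since it is carried onto a different core and rests on a single pair. In this assay compound 4 is therefore estimated at 4500 nM, with a likely range from 1000 nM to 20000 nM.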

Compound 4, half-maximal inhibitory concentration: 131000 nM
Compound 4: middle estimate off by 29-fold (1.46 log units), on the low side, and the stated range ends below it.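

In this assay, the same swap of the chloromethyl end for hydrogen gave a 2.2-fold higher number from compound 2 to compound 4 (0.34 log units; beyond the scatter), so on this core the shorter chain did not bring the stronger effect seen with compound 3. The change therefore cannot be carried from the core of compound 1 to the core of compound 2, in either size or direction: the same change on two cores in this assay, a 16-fold lower number (1.21 log units; beyond the scatter) from compound 1 to compound 3 and a 2.2-fold higher number (0.34 log units; beyond the scatter) from compound 2 to compound 4, 35-fold (1.55 log units) apart, beyond the scatter of two such steps This shows that the result of shortening the chain depends on the core it sits on, but with one pair on each core, and with cores that differ in more than one place, it does not show which part of the core is responsible or why.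

The compounds shown leave open how each core would respond to a different group at the chain end, such as an amine or a hydroxyl in place of the chlorine, or to a longer chain. Among these compounds, they also leave open which way a compound with only one of the core differences would go, for example a methyl group in place of the propyl group on the core of compound 1.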